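Nitro in Place of Trifluoromethyl: An Expected Loss

This account rests on a few compounds, and the source may have more. Where it says the series, first, only, none or still open, it means among the compounds named here.

Three compounds built on one shared core were tested in a functional assay on DU-145 cells (Homo sapiens) for antiproliferative activity, read by MTT assay, with a stated time of 72 h; a higher number here means a weaker inhibitor, a lower number a stronger inhibitor. Compound 1 `O=[N+]([O-])c1ccc(COc2ccc(Nc3ncnc4cc5c(cc34)OCCOCCO5)cc2)cc1` reaches only the limit of the assay, reported as > 100000 nM. Compound 2 `FC(F)(F)c1ccc(COc2ccccc2Nc2ncnc3cc4c(cc23)OCCOCCO4)cc1` likewise gives only a limit, reported as > 100000 nM. Among the measured compounds shown here, compound 3 `FC(F)(F)c1ccc(COc2ccc(Nc3ncnc4cc5c(cc34)OCCOCCOCCOCCO5)cc2)cc1` is the one member with a measured number, 8800 nM. For the measured compounds named here, it is therefore the only real value in the set; the other two sit at the assay limit (the limit of > 100000 nM in this assay, at which 2 of the 3 values shown sit).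

The unmeasured compound 4 `O=[N+]([O-])c1ccc(COc2ccc(Nc3ncnc4cc5c(cc34)OCCOCCOCCOCCO5)cc2)cc1` differs from compound 3 in a single spot: nitro in place of trifluoromethyl on an aromatic carbon, in words, nitro in place of trifluoromethyl on an aromatic carbon. Going by the values given here, no pair of measured compounds shows this same change, so nothing here directly sets the size of the step. The set does show that two of three members fall at the limit, and that only compound 3 gives a number at all, so a move away from its structure carries a real risk of returning to the limit.

The step from compound 3 to compound 4 is expected to be a modest weakening, a 2.8-fold higher number from compound 3 to compound 4 (0.45 log units; beyond the scatter), beyond the usual scatter but not dramatic. Compound 4 is estimated at 25000 nM, with a plausible range from 6000 nM to 100000 nM.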

Compound 4, half-maximal inhibitory concentration: > 100000 nM
Compound 4: a limit, no number; the forecaster's own chance of this, stated with the estimate: 35%; at least 4.0-fold (0.60 log units) between middle value and limit.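

Putting nitro in place of trifluoromethyl, on an aromatic carbon para to a large group, gives an at least 11-fold higher number from compound 3 to compound 4 (1.05 log units; beyond the scatter) in this assay, so the activity of compound 3 depends on what sits at this position. On these data alone, compound 4 gives only a limit, which means the step is a floor and its full size remains unknown. This is the first direct test of a change at this position, and it leaves compound 3 as the only compound shown with a real number: the limit of > 100000 nM in this assay, at which 3 of the 4 values shown sit.

The compounds shown do not explain why nitro does so much worse than trifluoromethyl here, as no measured property accompanies the change, and with only these two groups to compare, they cannot show what this position favours. As far as these compounds go, how an amine, a nitrile or a single chlorine atom would fare at the same position remains open, as does whether any such group could match or improve on compound 3.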